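From 4-carboxyphenyl to 2-carboxyphenyl on a sulfur

The compounds below may be only part of what the source reports. "The series", "measured", "known", "first", "only" and "open" are said of these compounds alone.

Measured so far in a functional assay on U-937 cells (Homo sapiens) for antagonist activity, read by calcium flux; on this read-out higher numbers stand for weaker inhibition and lower numbers for stronger inhibition
- compound 1 `CCCCCCCCCCCCOc1ccc(COc2cccc(C(=O)O)c2)nc1/C=C/C(=O)O` gives 580 nM
- compound 2 `CCCCCCCCCCCCOc1ccc(C[S+]([O-])c2ccc(C(=O)O)cc2)nc1/C=C/C(=O)O` gives 1300 nM

Of these two, compound 2 has the higher number, 1300 nM, and so the weaker inhibition. The next compound is compound 3 `CCCCCCCCCCCCOc1ccc(C[S+]([O-])c2ccccc2C(=O)O)nc1/C=C/C(=O)O`, where 2-carboxyphenyl stands in place of 4-carboxyphenyl on a sulfur: 2-carboxyphenyl in place of 4-carboxyphenyl on a sulfur. Within the data shown here, only one measured step bears on this, a 2.2-fold higher number from compound 1 to compound 2 (0.35 log units; beyond the scatter), a modest one that exchanges a whole group on a saturated chain carbon. Among the measured compounds shown here, no measured compound carries 2-carboxyphenyl, so that step gives only a rough idea of size and no direction. No shift beyond the scatter is therefore expected in this assay, though with wide uncertainty. The expected change is a 1.2-fold higher number from compound 2 to compound 3 (0.06 log units; within the scatter). For compound 3 the estimated value is 1500 nM, with an expected range of 500 nM to 4500 nM.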

Compound 3, half-maximal inhibitory concentration: 1500 nM
Compound 3: middle estimate and measured number agree at the digits printed, within the range that was stated.
By their numbers in this assay, from the lowest: compound 1; then compounds 2 and 3 (each within the scatter of the next).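

The exchange of 4-carboxyphenyl for 2-carboxyphenyl on the sulfur gives a 1.2-fold higher number from compound 2 to compound 3 (0.06 log units; within the scatter) in this assay and so leaves the number within the scatter, which means this assay does not separate the two groups at this place. The earlier compounds had shown the effect of a whole-group exchange on the saturated chain carbon, and that exchange with 2-carboxyphenyl on the sulfur gives a 2.6-fold higher number from compound 1 to compound 3 (0.41 log units; beyond the scatter) and stays beyond the scatter. Compound 1 thus keeps the lowest number against both sulfur compounds in this assay and neither carboxyphenyl placement on the sulfur changes that. No supporting measurement is available to explain these results.

From the compounds shown here alone, it remains open whether 3-carboxyphenyl on the same sulfur would match compound 2 and compound 3. Going by these compounds, it is also open whether a tetrazole in place of the carboxylic acid, or a shorter chain on the shared core, would move the number beyond the scatter.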